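The source may hold more compounds than are shown below. What is called first, only, known or untested is meant among the compounds shown, and "the series" means these compounds.

For the measured compounds named here, compound 1 `CC1(CC[C@H](c2ccc(C(=O)NCc3nn[nH]n3)cc2)N2C(=O)C(c3cc(Cl)cc(Cl)c3)=N[C@]23CC[C@@H](C(C)(C)C)CC3)CC1` gives the lower of the two numbers measured so far: in a functional assay on CHO cells for antagonist activity at Glucagon receptor (Homo sapiens), read by cAMP accumulation, with stated times of 30 min and 45 min (a higher number here means a weaker inhibitor, a lower number a stronger inhibitor), compound 1 gives 100 nM. Going by the values given here, the only other measured compound, compound 2 `CC(C)(C)CC[C@H](c1ccc(C(=O)NCC(=O)O)cc1)N1C(=O)C(c2cc(Cl)cc(Cl)c2)=N[C@]12CC[C@@H](C(C)(C)C)CC2`, gives 2700 nM in this assay, a higher number that lies beyond the usual scatter. Compound 3 `CCCCC[C@H](c1ccc(C(=O)NCc2nn[nH]n2)cc1)N1C(=O)C(c2cc(Cl)cc(Cl)c2)=N[C@]12CC[C@@H](C(C)(C)C)CC2` has not been measured yet; it differs from compound 1 in one place (propyl in place of 1-methylcyclopropyl on a saturated chain carbon, three bonds along the chain from an amide-type nitrogen in a ring and an aromatic carbon). A small exchange on a side chain of this kind is expected to move the number little, a 1.6-fold higher number from compound 1 to compound 3 (0.20 log units; within the scatter), at most slightly toward a weaker inhibitor. Compound 3 is therefore estimated at 160 nM in this assay, with a range from 50 nM to 500 nM.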

Compound 3, half-maximal inhibitory concentration: 130 nM
Estimate against measurement, compound 3: 1.2-fold (0.09 log units) above, and the stated range covers the measured number.
By their numbers in this assay, from the lowest: compounds 1 and 3 (each within the scatter of the next); then compound 2.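

Exchanging 1-methylcyclopropyl for propyl at this saturated chain carbon gives a 1.3-fold higher number from compound 1 to compound 3 (0.11 log units; within the scatter) in this assay. For this pair, then, the three-membered ring is not needed to hold the number, and an open chain serves as well. No measurement here points to a cause for this.

Still open, as far as these compounds go, is whether a much shorter chain such as methyl would hold the number too. From the compounds shown here alone, it is also open how a chain ending in an amine or a hydroxyl group would behave at this place.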